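Diarylamine series: piperidinyl in place of hydroxy

The compounds below may be only part of what the source reports. "The series", "measured", "known", "first", "only" and "open" are said of these compounds alone.

Compound 1 `Cc1cc(Nc2cc(F)cc(F)c2)nc(N)n1` in an assay on cells for inhibition of S-adenosylmethionine decarboxylase proenzyme (Homo sapiens), read by mass spectrometry, at pH 7.2 (a higher number here means a weaker inhibitor, a lower number a stronger inhibitor), gives > 180000 nM, a limit of the assay.
Compound 2 `Cc1cc(Nc2cc(Cl)c(Oc3ccccc3)c(Cl)c2)nc(N)n1` in this assay gives > 180000 nM, again only a limit.
Compound 3 `Cc1cc(Nc2cc(Cl)c(O)c(Cl)c2)nc(N)n1` in this assay gives > 180000 nM, likewise a limit.

Compound 3 therefore stands at a limit, and two further values around it are limits as well. Among the compounds with values here, the single step between measured compounds, a step that the two limits leave unreadable from compound 2 to compound 3, is unreadable, as both ends are limits. The next change is piperidin-1-yl in place of hydroxy on an aromatic carbon, giving compound 4 `Cc1cc(Nc2cc(Cl)c(N3CCCCC3)c(Cl)c2)nc(N)n1`. Within the data shown here, no measured step bears on it with a readable size; the only evidence is the limit of > 180000 nM in this assay, at which 3 of the 3 values shown sit. Hence no step beyond the scatter is expected in either direction, and compound 4 is estimated at a step that the limit leaves unreadable from compound 3 to compound 4. Compound 4 is expected near 200000 nM, in the range 50000 nM to 800000 nM, most likely reported again as a limit.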

Compound 4, half-maximal inhibitory concentration: > 180000 nM
Compound 4: no number, only a limit; the forecaster's own chance of this, stated with the estimate: 85%; the middle value does not contradict the limit.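

Within the data shown here, compound 2, compound 3 and compound 4 all stand at a limit, and no step to compound 4 can be read. The compounds shown leave open which change to the shared core, if any, gives a measurable value in this assay: the limit of > 180000 nM in this assay, at which 4 of the 4 values shown sit.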